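The compounds below may be only part of what the source reports. "The series", "measured", "known", "first", "only" and "open" are said of these compounds alone.

The measured compounds, with their values in an ADME assay on the whole organism with Oryza sativa as the target, tested at 1 uM; on this read-out higher numbers stand for a weaker effect at the one concentration tested and lower numbers for a stronger effect:

compound 1 `C[C@H](NC(=O)Nc1ccccc1F)c1ccccc1`: 92%
compound 2 `C[C@H](NC(=O)Nc1cccc(F)c1)c1ccccc1`: 94%
compound 3 `C[C@@H](NC(=O)Nc1cccc(F)c1F)c1ccccc1`: 99%

Compound 3 holds the highest of the three numbers in this assay, but its nearest neighbour, compound 2, stands within the scatter of it, and so does compound 1, the one furthest away. On these numbers, therefore, the three compounds cannot be told apart. Going by the values given here, no two of them differ in only one place, so the data give no measured step to lean on.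

Compound 4 `C[C@H](NC(=O)Nc1cccc(F)c1F)c1ccccc1` has not yet been measured. It departs from compound 3 in a single respect: the two compounds have the same atoms and bonds and differ only in configuration as drawn: 1 of 1 stereo elements differ; a stereocentre at a saturated chain carbon is drawn R in compound 3 and S in compound 4. Among the compounds with values here, with no measured step available and the three numbers all lying within the scatter of one another, the expected step of a number 4 percentage points lower from compound 3 to compound 4 (within the scatter) is small and is not expected to go beyond the scatter in either direction. In this assay compound 4 is expected to give about 95%, with a range from 85% to 100%.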

Compound 4, a percentage reported as activity, at one concentration (the size of the read-out at that concentration, not a potency): 100%
Beside the measured number, compound 4's estimate is 5 percentage points below it; the measured number falls inside the stated range.
By their numbers in this assay, from the lowest: compounds 1, 2, 3 and 4 (each within the scatter of the next).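

Going by these compounds alone, for the first time a measured step isolates the stereocentre at the saturated chain carbon: in this assay, going from R to S gives a number 1 percentage points higher from compound 3 to compound 4 (within the scatter), and the two drawn configurations are not told apart. This step can be read as one of configuration alone on a single fact: the fact that compounds 3 and 4 differ only in the configuration as drawn. Fluoro in place of hydrogen on an aromatic carbon also yields its first measured steps, a number 6 percentage points higher from compound 2 to compound 4 (within the scatter) and a number 8 percentage points higher from compound 1 to compound 4 (within the scatter), and neither separates the compounds in this assay.

Every change shown here is either a fluoro or a configuration, and none gives a step beyond the scatter. Going by these compounds, whether chloro or methoxy in place of fluoro, or a longer chain in place of the methyl at the stereocentre, would do so remains open.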